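Imidazoline biaryl ethers: thiophene to methylpyrazole at the ortho aryl

A few compounds are considered here, and "the series" means these few. Any claim that something is new, unique, unknown or untested is made for them only; others in the source may bear on it.

Measured so far:
compound 1, `Cc1cccc(-c2ccccc2OCC2=NCCN2)n1`, < 100000 nM
compound 2, `c1ccc(-c2ccsc2)c(OCC2=NCCN2)c1`, 12.6 nM

Compound 1 is described by `Cc1cccc(-c2ccccc2OCC2=NCCN2)n1`; in a functional assay for activation of Alpha-1D adrenergic receptor (Homo sapiens), read by calcium flux (on this read-out higher numbers stand for an effect only at larger amounts of compound and lower numbers for an effect already at smaller amounts), compound 1 gives only a limit, < 100000 nM, not a number. Within the data shown here, compound 2, `c1ccc(-c2ccsc2)c(OCC2=NCCN2)c1`, is the single compound with a number in this assay, where compound 2 gives 12.6 nM. Compound 3, `Cn1nccc1-c1ccccc1OCC1=NCCN1`, has not been measured in this assay. The change from compound 2 to compound 3 is 1-methyl-1H-pyrazol-5-yl in place of thiophen-3-yl on an aromatic carbon. Among the measured compounds shown here, no step between two measured compounds exists here, so the size of this change cannot be calibrated from within the set. The expectation is for a step beyond the scatter toward weaker activation, a 16-fold higher number from compound 2 to compound 3 (1.20 log units; beyond the scatter), with wide uncertainty. Compound 3 is estimated at 200 nM, between 20 nM and 3000 nM.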

Compound 3, half-maximal effective concentration: < 100000 nM
Compound 3: no number, only a limit; the forecaster's own chance of this, stated with the estimate: 15%; the middle value is on the limit's open side.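

Among these compounds, compound 3, like compound 1, gives only a limit and not a number, so no step from compound 2 to compound 3 can be read. The compounds shown leave open how far activation actually falls with 1-methyl-1H-pyrazol-5-yl in place of thiophen-3-yl.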